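The source may report more compounds than this note shows. Statements on the series, on what has been measured and on what is new or still open speak of the compounds shown alone.

Working notes on the series. Compound 1 `Cc1ccc(Nc2nc(-c3ccncc3)cs2)cc1` serves as the reference point. Within the data shown here, in a functional assay on RCC4 cells (Homo sapiens) for inhibition, read by XTT assay, with a stated time of 4 days (on this read-out higher numbers stand for weaker inhibition and lower numbers for stronger inhibition), compound 1 gives 2510 nM, the lowest of the three numbers measured so far. Compound 3 `Oc1ccc(Nc2nc(-c3ccncc3)cs2)cc1` gives 5370 nM in this assay, and compound 2 `CCN(c1cccc(C)c1)c1nc(-c2ccncc2)cs1` gives 40700 nM. Among the measured compounds shown here, only one measured pair differs in a single place: a 2.1-fold higher number from compound 1 to compound 3 (0.33 log units; beyond the scatter). Compound 1 and compound 2 differ in more than one place, so only their two values can be set side by side, and compound 2 clearly gives the higher number of the two.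

Compound 4 `Cc1ccc(Nc2nc(-c3ccncc3)cs2)cc1C` has not yet been measured in this assay. It differs from compound 1 by methyl in place of hydrogen on an aromatic carbon. For the measured compounds named here, no measured step adds a group to this ring; the single measured step, a 2.1-fold higher number from compound 1 to compound 3 (0.33 log units; beyond the scatter), exchanges the existing methyl for another group rather than adding a second one, so it speaks to the same ring but not to the same kind of change. Going by the values given here, with that as the only guidance, the expected step from compound 1 to compound 4 is a 1.3-fold lower number from compound 1 to compound 4 (0.10 log units; within the scatter) in this assay, which would not exceed the scatter. The estimate for compound 4 is therefore 2000 nM, with a range of 800 nM to 5000 nM.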

Compound 4, half-maximal inhibitory concentration: 6610 nM
Compound 4: middle estimate off by 3.3-fold (0.52 log units), on the low side; measured number outside the range, above it.
By their numbers in this assay, from the lowest: compound 1; then compounds 3 and 4 (each within the scatter of the next); then compound 2.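

Adding a methyl ortho to a methyl group and meta to a large group gives a 2.6-fold higher number from compound 1 to compound 4 (0.42 log units; beyond the scatter) in this assay, so a single added carbon at this position is enough to move the number beyond the scatter. Among these compounds, this is the first measured step that adds a group to this ring rather than exchanging one. Alongside a 2.1-fold higher number from compound 1 to compound 3 (0.33 log units; beyond the scatter), which exchanges the existing methyl for hydroxy, it means that both one-place changes to this ring in the series give a higher number than compound 1, with no exception among these two steps; nothing measured here accounts for the effect of the added methyl.

Going by these compounds, whether the higher number is particular to methyl at this position remains open, as does the question of whether a fluorine, a methoxy group or an amine on the same carbon would give a step of similar size. Also open, on these data alone, is whether the added methyl would give the same step without the neighbouring methyl group, for example with hydroxy in its place as in compound 3.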